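Adding a Methyl Group to a Compound Without Measured Effect

The source may report more compounds than this note shows. Statements on the series, on what has been measured and on what is new or still open speak of the compounds shown alone.

Measured so far:
- compound 1, `CC(C(=O)N1CCN(c2ccccc2)CC1)N1C(=O)CCC1=O`, gives 0% in a functional assay on the whole organism (strain Swiss) with Mus musculus as the target, in the maximal electroshock model, with a stated time of 2 h, at a dose of 100 mg/kg by the intraperitoneal route; a higher number here means a stronger effect of the compound at the dose given, a lower number a weaker effect
- compound 2, `CCC(C(=O)N1CCN(c2cccc(C(F)(F)F)c2)CC1)N1C(=O)CCC1=O`, gives 0% in this assay

The two measured compounds share a core, and in this assay compound 1 gives 0%, while compound 2 gives 0%. Compound 1 thus stands at the same reading as compound 2; the two values lie within the scatter of each other, and no difference between them can be read from these numbers. Neither compound shows any effect at the dose used.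

Compound 3, `Cc1cccc(N2CCN(C(=O)C(C)N3C(=O)CCC3=O)CC2)c1`, has not yet been tested. It differs from compound 1 in one place: methyl in place of hydrogen on an aromatic carbon. At one bond further out, the change reads phenyl to 3-methylphenyl.

Among the measured compounds shown here, no step between measured compounds is available to show how such a change moves the reading. For the measured compounds named here, the only guide is that compound 1 and compound 2 share the same reading. The expected step of no change at the digits printed from compound 1 to compound 3 (within the scatter) is therefore none beyond the scatter. For compound 3 the estimated reading in this assay is 0%, with a range from 0% to 15%.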

Compound 3, a percentage reported as activity, at one dose (the size of the read-out at that dose, not a potency): 0%
Compound 3: middle estimate and measured number agree at the digits printed; measured number inside the range.
By their numbers in this assay, from the lowest: compounds 1, 2 and 3 (each within the scatter of the next).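

Among the compounds shown here, the single change of methyl in place of hydrogen on an aromatic carbon gives, in this assay, no change at the digits printed from compound 1 to compound 3 (within the scatter) and is the first direct test of this position. At this place, meta to a large group, adding one carbon is therefore not enough to bring out a measurable effect in a compound that starts without one, but a compound with no effect can show only a gain, not a loss, so the step cannot tell whether the methyl would harm activity in a compound that does have some. Nothing among the data shown gives a reason for this result.

The compounds shown leave open whether another group at this same place, such as an amine, a carboxylic acid or a longer chain, would give a reading different from that of compound 1. They also leave open what the change from phenyl to 3-methylphenyl would do on a related compound with a clear reading in this assay, where a step in either direction could be seen.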